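Methyl for 4-methylphenyl on the ring amine nitrogen

The source may report more compounds than this note shows. Statements on the series, on what has been measured and on what is new or still open speak of the compounds shown alone.

For the measured compounds named here, compound 2 `Cc1ccc(N2CCN(C(=S)SCc3ccc(C(=O)Nc4ccccc4N)cc3)CC2)cc1` gives 25.3% in a functional assay on HeLa cells (Homo sapiens) for antiproliferative activity, read by CCK-8 assay, with a stated time of 72 h, tested at 2 uM (a lower number here means a weaker effect, a higher number a stronger effect of the compound at the concentration tested), the lowest of the two numbers measured so far. Going by the values given here, compound 1 `N#Cc1ccc(N2CCN(C(=S)SCc3ccc(C(=O)Nc4ccccc4N)cc3)CC2)cc1` gives 71.6% in this assay; the only measured step, a number 46.3 percentage points lower from compound 1 to compound 2 (beyond the scatter), concerns the group on the aromatic carbon of the six-membered aromatic ring. Compound 3 `CN1CCN(C(=S)SCc2ccc(C(=O)Nc3ccccc3N)cc2)CC1` differs from compound 2 by methyl in place of 4-methylphenyl on an amine nitrogen in a ring. Among the compounds with values here, no measured step bears directly on this change: the one known step exchanges a group on that aromatic ring rather than removing the ring itself, so it offers no guide to the size of the step in this assay. With compound 2 already low in this assay at 25.3%, the expected step is a number 3.3 percentage points lower from compound 2 to compound 3 (within the scatter), not beyond the scatter in either direction. Compound 3 is therefore estimated at 22%, with a range of 5% to 45%.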

Compound 3, a percentage reported as inhibition, at one concentration (the size of the read-out at that concentration, not a potency): 52.6%
The estimate for compound 3 lay 30.6 percentage points below the measured number; measured number outside the range, above it.
By their numbers in this assay, from the lowest: compound 2; then compound 3; then compound 1.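

In this assay an aromatic ring on the amine nitrogen in a ring is not required for a sizeable number: with methyl in place of 4-methylphenyl there is a number 27.3 percentage points higher from compound 2 to compound 3 (beyond the scatter), whereas with methyl in place of 4-cyanophenyl there is a number 19 percentage points lower from compound 1 to compound 3 (beyond the scatter). The same entering methyl therefore moves the number in opposite directions, and the outcome depends on which group leaves, so the aromatic ring at this position cannot be judged apart from the group it carries. Nothing at hand accounts for either step.

Open, as far as these compounds go, is how an ethyl group, a longer chain or a plain hydrogen on this nitrogen would compare with methyl. Also open, from the compounds shown here alone, is where a phenyl ring carrying methoxy, chlorine or a carboxylic acid would fall relative to the 4-methylphenyl and 4-cyanophenyl groups.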